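A few compounds are considered here, and "the series" means these few. Any claim that something is new, unique, unknown or untested is made for them only; others in the source may bear on it.

Measured so far in a functional assay on HCT-116 cells (Homo sapiens) for cytotoxicity, read by MTT assay, with a stated time of 72 h; on this read-out lower numbers stand for stronger inhibition and higher numbers for weaker inhibition:
- compound 1 `COc1ccc(/C=C2\S/C(=N\c3csc(-c4ccc(Cl)cc4)c3)NC2=O)cc1` gives 1300 nM
- compound 2 `CN(C)c1ccc(/C=C2\S/C(=N\c3csc(-c4ccc(Cl)cc4)c3)NC2=O)cc1` gives 500 nM
- compound 3 `O=C1N/C(=N/c2csc(-c3ccc(Cl)cc3)c2)S/C1=C\c1ccc2ccccc2c1` gives 3000 nM

Compound 3 stands at the highest of the three numbers. Its nearest neighbour is compound 1, with a 2.3-fold higher number from compound 1 to compound 3 (0.36 log units; beyond the scatter); the furthest is compound 2, with a 6.0-fold higher number from compound 2 to compound 3 (0.78 log units; beyond the scatter). Within the phenyl pair, a 2.6-fold lower number from compound 1 to compound 2 (0.41 log units; beyond the scatter).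

Compound 4 `O=C1N/C(=N/c2csc(-c3ccc(Cl)cc3)c2)S/C1=C\c1ccc(F)cc1` is the next step from compound 3: 4-fluorophenyl in place of naphthalen-2-yl on a double-bonded chain carbon bound to a double-bonded ring carbon.

Among the compounds with values here, two measured steps bear on this change, as both replace the naphthalen-2-yl of compound 3 with a para-substituted phenyl. Both run the same way: the phenyl analogues, compound 1 and compound 2, give the lower numbers, by modest margins beyond the scatter. Within the data shown here, the substituent on the entering phenyl in compound 4 is fluorine, which has no direct precedent in the shared core, so the size of the shift is uncertain; the direction, however, is expected to follow compound 1 and compound 2, since a 2.3-fold higher number from compound 1 to compound 3 (0.36 log units; beyond the scatter) and a 6.0-fold higher number from compound 2 to compound 3 (0.78 log units; beyond the scatter) both point toward lower numbers for a single-ring group in this place.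

Compound 4 is therefore expected to give a modestly lower number than compound 3, a step of about a 2.0-fold lower number from compound 3 to compound 4 (0.30 log units; within the scatter) in this assay. The estimate for compound 4 is 1500 nM, with a range from 500 nM to 4500 nM.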

Compound 4, half-maximal inhibitory concentration: 7400 nM
Beside the measured number, compound 4's estimate is 4.9-fold (0.69 log units) below it, outside the stated range (above it).
By their numbers in this assay, from the lowest: compound 2; then compound 1; then compound 3; then compound 4.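

In this assay a single-ring group at this place does not by itself give a lower number than naphthalen-2-yl: there is a 2.5-fold higher number from compound 3 to compound 4 (0.39 log units; beyond the scatter) and so compound 4 goes against the direction set by compound 1 and compound 2. The outcome therefore depends on the substituent on the phenyl and not simply on replacing the fused rings, with a 5.7-fold higher number from compound 1 to compound 4 (0.76 log units; beyond the scatter) for fluoro in place of methoxy and a 15-fold higher number from compound 2 to compound 4 (1.17 log units; beyond the scatter) for fluoro in place of dimethylamino, the latter being the only large step among these compounds. Across compound 2, compound 1 and compound 4, the numbers rise in the order dimethylamino, methoxy, fluoro, but no measurement available here accounts for this order.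

Three substituents cannot separate a general trend from features particular to each group, and an unsubstituted phenyl would be needed as a reference for the direction of each substituent's step. On these data alone, it also remains open whether a morpholine, a hydroxyl or a carboxylic acid on the same aromatic carbon would fall near dimethylamino or near fluoro.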